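Series notes: acyl-sulfonamide ureas, half-life, bromo position

The source may report more compounds than this note shows. Statements on the series, on what has been measured and on what is new or still open speak of the compounds shown alone.

Measured so far:
compound 1 `O=C(NCC1CCCCC1)N1C(=O)c2ccccc2S1(=O)=O` — 0.963 h
compound 2 `COc1ccc(CNC(=O)N2C(=O)c3ccccc3S2(=O)=O)cc1` — 0.187 h
compound 3 `O=C(NCc1ccc(Br)cc1)N1C(=O)c2ccccc2S1(=O)=O` — 0.187 h

In a physicochemical assay for pharmacokinetics (a lower number here means that the compound disappears faster, a higher number that the compound lasts longer), compound 3 gives 0.187 h. It stands level with compound 2 at the digits shown, the two together being the lowest of the three numbers, and it lies no change at the digits printed from compound 2 to compound 3 (within the scatter). Compound 1 sits furthest from it; the step runs a 5.1-fold lower number from compound 1 to compound 3 (0.71 log units; beyond the scatter), and the matching step to compound 2 runs a 5.1-fold lower number from compound 1 to compound 2 (0.71 log units; beyond the scatter).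

Compound 4 `O=C(NCc1cccc(Br)c1)N1C(=O)c2ccccc2S1(=O)=O` is not yet measured. It differs from compound 3 only in the arrangement of the same atoms: 3-bromophenyl in place of 4-bromophenyl on a saturated chain carbon bound to an amide-type nitrogen.

Among the measured compounds shown here, no measured step moves a group around the aromatic ring, so none bears directly on this change. For the measured compounds named here, the only step that touches the ring, no change at the digits printed from compound 2 to compound 3 (within the scatter), swaps one group for another in the same place and stays within the scatter, while the two larger steps both replace cyclohexyl with an aryl ring. Taken together, the expected step for compound 4 is a 1.1-fold higher number from compound 3 to compound 4 (0.03 log units; within the scatter), that is, none beyond the scatter.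

Compound 4 is therefore estimated at 0.2 h in this assay, expected to fall between 0.1 h and 0.4 h.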

Compound 4, half-life: 0.492 h
Compound 4: middle estimate off by 2.5-fold (0.39 log units), on the low side; measured number above the stated range.
By their numbers in this assay, from the lowest: compounds 2 and 3 (each within the scatter of the next); then compounds 4 and 1 (each within the scatter of the next).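

In this assay, the arrangement of the ring matters even with the same atoms: 3-bromophenyl in place of 4-bromophenyl on the saturated chain carbon gives a 2.6-fold higher number from compound 3 to compound 4 (0.42 log units; beyond the scatter), whereas bromo in place of methoxy gave no change at the digits printed from compound 2 to compound 3 (within the scatter), with no step beyond the scatter. 3-Bromophenyl also stands apart from 4-methoxyphenyl, with a 2.6-fold higher number from compound 2 to compound 4 (0.42 log units; beyond the scatter), while its step from cyclohexyl, a 2.0-fold lower number from compound 1 to compound 4 (0.29 log units; within the scatter), stays within the scatter, so an aryl ring in this place does not always give a step beyond the scatter from cyclohexyl. No measurement at hand accounts for the step between the two bromophenyl compounds.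

Among the compounds shown here, only one pair of compounds moves a group around the ring, so it remains open whether this step holds for any group other than bromo. Also open, going by these compounds, is how an amine or a carboxylic acid on the aromatic ring, or a longer chain in place of the saturated chain carbon, would read in this assay here.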